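A few compounds are considered here, and "the series" means these few. Any claim that something is new, unique, unknown or untested is made for them only; others in the source may bear on it.

Compound 1 `O=C(C1CC12CCC2)N1CCc2nc(C#Cc3ccccc3)sc2C1` in an assay on HEK293 cells for positive allosteric modulation of metabotropic glutamate receptor 5 (Homo sapiens), read by FLIPR, with a stated time of 1 h (on this read-out lower numbers stand for an effect already at smaller amounts and higher numbers for an effect only at larger amounts of compound), gives 3.9 nM.
Compound 2 `Cc1nc(C(=O)N2CCc3nc(C#Cc4ccccc4)sc3C2)cs1` gives 220 nM.
Compound 3 `O=S(=O)(C1CC1)N1CCc2nc(C#Cc3ccccc3)sc2C1` reaches only a limit of the assay, > 10000 nM, not a number.

Compound 3 thus sits at the limit of > 10000 nM in this assay, at which 1 of the 3 values shown sits, apart from the other two. Compound 4 `O=C(N1CCCC1)N1CCc2nc(C#Cc3ccccc3)sc2C1` differs from it by (pyrrolidin-1-yl)carbonyl in place of cyclopropylsulfonyl on an amine nitrogen in a ring. Both measured steps at this position are large and run the other way: an at least 2500-fold higher number from compound 1 to compound 3 (3.40 log units; beyond the scatter) and an at least 45-fold higher number from compound 2 to compound 3 (1.65 log units; beyond the scatter). Each of them replaced a carbonyl-linked group by cyclopropylsulfonyl; compound 4 returns to a carbonyl-linked group, so the reverse of such a step is expected, a large move toward lower numbers, an at least 66-fold lower number from compound 3 to compound 4 (1.82 log units; beyond the scatter). Whether it lands nearer compound 1 or compound 2 the data do not tell. Compound 4 is expected at 150 nM, within 15 nM to 2500 nM.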

Compound 4, half-maximal effective concentration: 9.8 nM
For compound 4 the middle estimate is 15-fold (1.18 log units) above the measured one; the whole stated range lies above it.
By their numbers in this assay, from the lowest: compound 1; then compound 4; then compound 2. At a limit, above all of these: compound 3.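

Returning from cyclopropylsulfonyl to a carbonyl-linked group gives an at least 1000-fold lower number from compound 3 to compound 4 (3.00 log units; beyond the scatter); the start of that step is a limit of the assay, not a number. On the carbonyl carbon, the aromatic 2-methyl-1,3-thiazol-4-yl group gives way to pyrrolidin-1-yl with a 22-fold lower number from compound 2 to compound 4 (1.35 log units; beyond the scatter), which shows that a non-aromatic ring with a nitrogen can serve here. Against the all-carbon group of compound 1, the same ring gives only a 2.5-fold higher number from compound 1 to compound 4 (0.40 log units; beyond the scatter).

As far as these compounds go, whether a piperidine ring or an open-chain dimethylamino group on the carbonyl carbon would stay in this range remains open. So does whether a methylsulfonyl group would behave like cyclopropylsulfonyl.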